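The compounds below may be only part of what the source reports. "The series", "measured", "known", "first", "only" and "open" are said of these compounds alone.

Measured compounds:
Compound 1 `O=C(/C=C\Nc1ccc(F)cc1)c1cn(-c2ccccc2)nc1-c1ccccc1` — 6870 nM
Compound 2 `O=C(/C=C\Nc1ccc(Cl)cc1)c1cn(-c2ccccc2)nc1-c1ccccc1` — 3610 nM

Among the compounds with values here, in a functional assay on HT-29 cells (Homo sapiens) for antiproliferative activity, read by MTT assay, with a stated time of 48 h (a higher number here means a weaker inhibitor, a lower number a stronger inhibitor), compound 2 stands lowest of the two numbers so far. Within the data shown here, its nearest neighbour is compound 1, and the only step between measured compounds, a 1.9-fold lower number from compound 1 to compound 2 (0.28 log units; within the scatter), lies within the scatter, so the two cannot be ranked against each other on this evidence.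

Compound 3 `O=C(/C=C\Nc1ccc(C(F)(F)F)cc1)c1cn(-c2ccccc2)nc1-c1ccccc1` is the next compound to consider. It differs from compound 2 in one place: trifluoromethyl in place of chloro on an aromatic carbon. Among the measured compounds shown here, the single step that bears on this change is the one from compound 1 to compound 2, which also exchanged one group at this same aromatic carbon and produced only a 1.9-fold lower number from compound 1 to compound 2 (0.28 log units; within the scatter). For the measured compounds named here, there is no measured example of a trifluoromethyl group at this place, so the expectation rests on that one step alone. A change of similar kind at the same place is therefore expected to give a step of a size not clearly beyond the scatter, with the direction uncertain; the expected step reads a 1.3-fold lower number from compound 2 to compound 3 (0.11 log units; within the scatter).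

Compound 3 is accordingly estimated at 2800 nM in this assay, with a range from 900 nM to 9000 nM.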

Compound 3, half-maximal inhibitory concentration: > 50000 nM
Compound 3: no number, only a limit (the forecaster's own chance of this, stated with the estimate: 5%); middle value at least 17-fold (1.25 log units) away from the limit.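

In this assay compound 3 gives > 50000 nM, which is a limit and not a number: the limit of > 50000 nM in this assay, at which 1 of the 3 values shown sits.

The earlier pair gave no sign that this aromatic carbon, para to a large group, was sensitive to the group it carries, since the exchange of fluoro for chloro gave only a 1.9-fold lower number from compound 1 to compound 2 (0.28 log units; within the scatter). With trifluoromethyl the picture changes: the exchange for chloro gives an at least 13-fold higher number from compound 2 to compound 3 (1.14 log units; beyond the scatter) and the exchange for fluoro gives an at least 7.2-fold higher number from compound 1 to compound 3 (0.86 log units; beyond the scatter), both beyond the scatter, so the activity in this series does depend on what sits at this place.

The three compounds do not tell what separates trifluoromethyl from the two halogens, or whether a methyl, a methoxy, a nitrile or an amine at this carbon would stay with compound 1 and compound 2 or fall with compound 3. Going by these compounds, how far the true value of compound 3 lies past its limit also stays open, as does whether the same exchange would have a similar effect with other groups on the shared core.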